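A Vinyl for a Methyl: What to Expect of Compound 4

This account rests on a few compounds, and the source may have more. Where it says the series, first, only, none or still open, it means among the compounds named here.

Of the compounds shown here, three have so far been tested in a functional assay on the whole organism (strain albino) for inhibition, with Rattus norvegicus as the target, read by paw edema, with a stated time of 3 h, at a dose of 0.28 mmol/kg by the oral route; on this read-out lower numbers stand for less inhibition and higher numbers for more inhibition at the one dose given (going by the name of the read-out). Compound 1 `C=CCn1c(SCC(=O)c2ccccc2)nnc1-c1ccccc1` gives 70% in this assay. Compound 2 `CCn1c(SCC(=O)c2ccccc2)nnc1-c1ccccc1` gives 61% in this assay. These two compounds differ in one place only, namely (vinyl in place of methyl on a saturated chain carbon bound to an aromatic nitrogen), and the measured step is a number 9 percentage points higher from compound 2 to compound 1 (within the scatter), so the two values cannot be told apart within the usual scatter.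

Compound 3 `CCn1c(SC/C(=N/O)c2ccccc2)nnc1-c1cc(OC)c(OC)c(OC)c1` gives 69% in this assay. Its value is within the scatter of both compound 1 and compound 2. How the core of compound 3 differs from the core of compound 2 is not broken down here.

Compound 4 `C=CCn1c(SC/C(=N/O)c2ccccc2)nnc1-c1cc(OC)c(OC)c(OC)c1` has not yet been measured. It differs from compound 3 by vinyl in place of methyl on a saturated chain carbon bound to an aromatic nitrogen. This is the same change that separates compound 2 from compound 1, at the same place in the molecule, and among the compounds shown it occurs twice in all.

Within the data shown here, the expectation for compound 4 rests on the one measured instance of this change, the step of a number 9 percentage points higher from compound 2 to compound 1 (within the scatter), which lay within the scatter. For compound 4 the step expected in this assay is therefore a number 4 percentage points higher from compound 3 to compound 4 (within the scatter). Compound 4 is thus estimated at 73%, with a range expected from 58% to 85%.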

Compound 4, a percentage reported as inhibition, in the whole organism at one dose (the size of the read-out at that dose, not a potency): 70%
The estimate for compound 4 lay 3 percentage points above the measured number, and the stated range covers the measured number.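

In this assay, putting vinyl in place of methyl on a saturated chain carbon bound to an aromatic nitrogen, the difference that also reads as ethyl to allyl, gives a number 1 percentage points higher from compound 3 to compound 4 (within the scatter) on the core of compound 3. Set beside the earlier instance of the change, this second step cannot be told apart from the first: the same change on two cores in this assay, a number 9 percentage points higher (within the scatter) from compound 2 to compound 1 and a number 1 percentage points higher (within the scatter) from compound 3 to compound 4, 8 percentage points apart, within the scatter of two such steps. The change can therefore be carried from one core to the other in this series without any measured disagreement between the two steps, but since neither step lies beyond the scatter, this does not show that the change has a real effect on inhibition on either core, nor that the agreement would hold on a third core.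

The compounds shown carry only ethyl and allyl at this place, so they leave open what a longer chain such as butyl, a benzyl group, or a chain ending in an amine or a carboxylic acid would give on either core. They also leave open whether the two steps would still agree at other doses or at other times, as everything here rests on a single dose and a single reading.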